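The source may report more compounds than this note shows. Statements on the series, on what has been measured and on what is new or still open speak of the compounds shown alone.

Compound 1 `Cc1ccc(C(=O)N/N=C/c2cc(I)cc(I)c2O)cc1` was tested in a functional assay on HepG2 cells (Homo sapiens) for cytotoxicity, with a stated time of 24 h; a higher number here means a weaker inhibitor, a lower number a stronger inhibitor. In this assay compound 1 gives only a limit, > 25000 nM, and no number. That is all that is known of where compound 1 stands: the limit of > 25000 nM in this assay, at which 1 of the 2 values shown sits. Compound 2 `O=C(N/N=C/c1cc(I)cc(I)c1O)c1ccc(Cl)cc1` differs from compound 1 by chloro in place of methyl on an aromatic carbon, and in this assay compound 2 gives 14800 nM. That step shows an at least 1.6-fold lower number from compound 1 to compound 2 (0.22 log units; that floor lies within the scatter), so no change beyond the scatter can be claimed from it. Compound 3 `O=C(N/N=C/c1cc(I)cc(I)c1O)c1ccc([N+](=O)[O-])cc1` has not yet been measured. It differs from compound 1 as follows: nitro in place of methyl on an aromatic carbon. Among the measured compounds shown here, the only measured step that bears on this change is the one from compound 1 to compound 2, where another group replaces the same methyl on the same aromatic carbon, and that step at its floor stayed within the scatter. A step of similar size is therefore expected for compound 3, toward a lower number if anything, an at least 1.6-fold lower number from compound 1 to compound 3 (0.22 log units; that floor lies within the scatter). Compound 3 is estimated at 15000 nM, with a range from 6000 nM to 40000 nM.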

Compound 3, half-maximal inhibitory concentration: 24700 nM
For compound 3 the middle estimate is 1.6-fold (0.22 log units) below the measured one, within the range that was stated.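

Among the compounds shown here, compound 3 gives the first comparison at this position between two real numbers, and in this assay it reads a 1.7-fold higher number from compound 2 to compound 3 (0.22 log units; within the scatter), so nitro and chloro on this aromatic carbon cannot be told apart. Against the methyl of compound 1, the change to nitro reads an at least 1.0-fold lower number from compound 1 to compound 3 (0.00 log units; that floor lies within the scatter), and no change can be claimed from that floor. Methyl therefore remains unplaced against both other groups, because its result is a limit and not a number: the limit of > 25000 nM in this assay, at which 1 of the 3 values shown sits.

The compounds shown leave open whether any replacement of the methyl at this place moves the number beyond the scatter, and whether methyl itself differs from chloro or nitro at all. With only these three groups in view, an amine or a carboxylic acid on this same aromatic carbon remains an open case, as does any change elsewhere on the shared core.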